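The source may hold more compounds than are shown below. What is called first, only, known or untested is meant among the compounds shown, and "the series" means these compounds.

Measured in a functional assay on HeLa cells (Homo sapiens) for inhibition, read by MTT assay, with a stated time of 24 h, tested at 5 uM; a higher number here means more inhibition of growth at the concentration tested, a lower number less inhibition of growth:
compound 1 `N#Cc1ccc(-c2cnc3[nH]cc(-c4nnc(-c5ccc(Cl)cc5)o4)c(=O)c3c2)cc1` — 4.8%
compound 2 `CS(=O)(=O)c1ccc(-c2cnc3[nH]cc(-c4nnc(-c5ccc(F)cc5)o4)c(=O)c3c2)cc1` — 8.47%
compound 3 `O=c1c(-c2nnc(-c3ccc(Cl)cc3)o2)c[nH]c2ncc(-c3ccccc3)cc12` — 3.55%

Compound 2 gives the highest of the three numbers, but its margin to compound 1 and to compound 3 falls within the scatter, so the three compounds stand together at a low level of growth inhibition and none can be set apart from the others. Among the measured compounds shown here, the only step measured between two compounds that differ in one place is a number 1.3 percentage points lower from compound 1 to compound 3 (within the scatter); it too is within the scatter.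

Compound 4 `Cc1cccc(-c2nnc(-c3c[nH]c4ncc(-c5ccc(S(C)(=O)=O)cc5)cc4c3=O)o2)c1` has not yet been measured in this assay. It differs from compound 2 in one place: 3-methylphenyl in place of 4-fluorophenyl on an aromatic carbon. For the measured compounds named here, no measured step concerns this place; the single step available, hydrogen in place of cyano on an aromatic carbon, sits on another part of the shared core and did not move the number beyond the scatter. With nothing in the three measured compounds pointing to a change, the number for compound 4 is expected to stay close to that of compound 2, and a number 1.5 percentage points lower from compound 2 to compound 4 (within the scatter) is expected to lie within the scatter. For compound 4 the estimate in this assay is 7%, with a range from 0% to 18%.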

Compound 4, percent growth inhibition at one concentration: 1.49%
Estimate against measurement, compound 4: 5.5 percentage points above; the measured number falls inside the stated range.
By their numbers in this assay, from the lowest: compounds 4, 3, 1 and 2 (each within the scatter of the next).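

In this assay the place on the five-membered aromatic ring with 2 nitrogen and 1 oxygen, next to the ring nitrogen and next to the ring oxygen, now has a measured step of its own: a number 7 percentage points lower from compound 2 to compound 4 (within the scatter). This exchange of 4-fluorophenyl for 3-methylphenyl keeps the heavy-atom count and the single six-membered aromatic ring of carbon only, and it leaves compound 2 and compound 4 indistinguishable, so all four compounds remain together at a low level of growth inhibition at the concentration tested. Nothing shown here gives a measured reason for these readings or ties a property to either group.

Still open, on these data alone, is whether an amine or a carboxylic acid on the aromatic ring at this place, or a longer chain in place of that ring, would move the number beyond the scatter. As far as these compounds go, each exchange also rests on a single pair, so it remains unknown whether 3-methylphenyl would read the same alongside the other groups carried at the far end of the shared core.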